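Series notes: benzyloxy to methoxy on the pyridyl bicyclic amines

The source may hold more compounds than are shown below. What is called first, only, known or untested is meant among the compounds shown, and "the series" means these compounds.

Three compounds have numbers in an in vitro assay on SH-SY5Y cells for displacement of a labelled ligand from Neuronal acetylcholine receptor; alpha3/beta4 (Homo sapiens); on this read-out lower numbers stand for stronger inhibition and higher numbers for weaker inhibition. Compound 1 `Clc1ccncc1C1=CC2CNCC(C1)C2` gives 128 nM in this assay. Compound 2 `C1=C(c2cncc(OCc3ccccc3)c2)CC2CNCC1C2` gives 44 nM in this assay. Compound 3 `CN1C[C@H]2C=C(c3cccnc3)C[C@H](C2)C1` gives 534 nM in this assay. Compound 2 has the lowest number of the three: compound 1 lies beyond the scatter from it, and compound 3 lies further out still, so compound 2 stands as the strongest binder among the compounds measured here. No two of these compounds differ in only one place, so no single step can be read from the measured numbers.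

Compound 4 `COc1cncc(C2=CC3CNCC(C2)C3)c1` has not yet been measured in this assay. It differs from compound 2 by hydrogen in place of phenyl on a saturated chain carbon bound to an oxygen on an aromatic ring. The measured compounds show that the substituent on the pyridyl ring carries weight: compound 1 with chlorine and compound 3 with no substituent both sit at higher numbers than compound 2, though compound 3 also differs at the ring amine, so the comparison is not clean. Compound 4 is expected to move toward a higher number in this assay, with a step of a 3.4-fold higher number from compound 2 to compound 4 (0.53 log units; beyond the scatter) expected beyond the scatter. Compound 4 is estimated at 150 nM, within 50 nM to 450 nM.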

Compound 4, inhibition constant: 14.3 nM
Estimate against measurement, compound 4: 10-fold (1.02 log units) above, and the stated range ends above it.
By their numbers in this assay, from the lowest: compound 4; then compound 2; then compound 1; then compound 3.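

In this assay, among these compounds, cutting benzyl back to methyl gives a 3.1-fold lower number from compound 2 to compound 4 (0.49 log units; beyond the scatter), which is the first single-place step and lies beyond the scatter. At this place, on a saturated chain carbon bound to an oxygen on an aromatic ring, the phenyl is therefore not needed for a low number, and hydrogen in its place goes with stronger inhibition. The step comes from a single pair, and nothing measured here bears on why the number falls with the loss of the phenyl.

The compounds shown leave open how the read-out behaves between and around these two groups: an ethyl or a longer chain on the oxygen, a hydroxyl in place of the methoxy, or a benzyl carrying a fluorine on its ring could show whether the number changes steadily with the group or only with the loss of the phenyl. Going by these compounds, it also remains open whether the same benzyl to methyl change gives a step of similar size on a core carrying a methyl on the ring amine.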